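This account rests on a few compounds, and the source may have more. Where it says the series, first, only, none or still open, it means among the compounds named here.

Measured so far in an ADME assay on microsomes from liver (Mus musculus) for metabolic stability (on this read-out lower numbers stand for slow clearance and higher numbers for fast clearance), for three compounds of the series:

- Compound 1 `O=C(NCc1ccc(Cl)cc1)c1ncc2cccnc2c1O` gives 10 mL.min-1.g-1
- Compound 2 `CNc1ccnc2c(O)c(-c3nc(C)n[nH]3)ncc12` gives 3.1 mL.min-1.g-1
- Compound 3 `COc1ccccc1-c1nc(-c2nnc(C)o2)c(O)c2ncccc12` gives < 0.5 mL.min-1.g-1 as a limit

Compound 1 at 10 mL.min-1.g-1 holds the higher of the two actual numbers, and compound 2 at 3.1 mL.min-1.g-1 lies lower by a gap beyond the usual scatter. The entry for compound 3 is a limit and not a number.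

Still unmeasured is compound 4 `COc1ccc(CNC(=O)c2ncc3cccnc3c2O)cc1`, which carries methoxy in place of chloro on an aromatic carbon, para to a large group methoxy in place of chloro on an aromatic carbon and otherwise matches compound 1. Among the measured compounds shown here, no measured pair covers this change, so the direction of any shift remains an expectation with little support. For the measured compounds named here, the anchor is compound 1 at 10 mL.min-1.g-1 in this assay, the only measured compound that differs from compound 4 in this one place. A small rise in clearance that stays within the scatter is expected, and the estimated step is a 1.3-fold higher number from compound 1 to compound 4 (0.11 log units; within the scatter) on that reading. For compound 4 the expected value is 13 mL.min-1.g-1 with an estimated range of 5 mL.min-1.g-1 to 32 mL.min-1.g-1 in this read-out.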

Compound 4, intrinsic clearance in microsomes in the Mus musculus assay: 2.6 mL.min-1.g-1
The estimate for compound 4 lay 5.0-fold (0.70 log units) above the measured number; measured number below the stated range.
By their numbers in the Mus musculus assay, from the lowest: compounds 4 and 2 (each within the scatter of the next); then compound 1. At a limit, below all of these: compound 3.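

Among the compounds shown here, in the Mus musculus assay, methoxy in place of chloro on an aromatic carbon, para to a large group, gives a 3.8-fold lower number from compound 1 to compound 4 (0.59 log units; beyond the scatter), the first step that reads this position directly. For the compounds shown here, the clearance read-out therefore responds to the group at this place alone, with the rest of the structure of compound 1 unchanged, although nothing measured so far accounts for the size or direction of the step. In a physicochemical assay for solubility, measured as kinetic solubility (a higher number here means a more soluble compound, a lower number a less soluble compound), compound 1 gives > 250000 nM, which is a limit of the assay and not a number. In the physicochemical assay compound 4 gives > 250000 nM, which is likewise a limit of the assay and not a number. In the physicochemical assay the step for this change cannot be read, as compound 1 and compound 4 both sit at a limit of the assay: the limit of > 250000 nM in the physicochemical assay, at which 2 of the 2 values shown sit.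

A single pair cannot separate what leaving chloro contributes from what entering methoxy contributes, nor show whether the step would recur on a different core. Also open, going by these compounds, is where other groups at the same place, such as fluoro, an amine or a carboxylic acid, would fall in the Mus musculus assay relative to chloro and methoxy, and whether any of them would bring the solubility read-out away from its limit.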